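Does a fluoro on compound 3 shift the number?

The source may hold more compounds than are shown below. What is called first, only, known or untested is meant among the compounds shown, and "the series" means these compounds.

Measured so far in a functional assay on MCF-10A cells (Homo sapiens) for antiproliferative activity, with a stated time of 48 h; a higher number here means that more compound is needed for the effect, a lower number that less compound is needed
- compound 1 `COc1ccc2nc(C)cc(NCc3ccc(F)c(F)c3)c2c1` gives 9100 nM
- compound 2 `COc1ccc2nc(C)cc(NCc3ccc(F)c(C(F)(F)F)c3)c2c1` gives 11300 nM
- compound 3 `COc1cccc(CNc2cc(C)nc3ccc(OC)cc23)c1` gives 9700 nM

The three values lie so close together that compound 3 cannot be separated from either neighbour, since both gaps fall within the usual scatter of repeated measurements. Compound 4 `COc1ccc2nc(C)cc(NCc3ccc(F)c(OC)c3)c2c1` has not yet been measured in this assay. It carries fluoro in place of hydrogen on an aromatic carbon of compound 3, ortho to a methoxy group and para to a large group (fluoro in place of hydrogen on an aromatic carbon).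

Among the compounds with values here, only one measured step changes a single place, a 1.2-fold higher number from compound 1 to compound 2 (0.09 log units; within the scatter). It swaps a different pair of groups, so it offers only indirect guidance, but it stays within the scatter. No step beyond the scatter is therefore expected in this assay, and no direction can be favoured. The expected step is a 1.0-fold higher number from compound 3 to compound 4 (0.01 log units; within the scatter). For compound 4 the estimated value is 10000 nM, with an expected range from 6000 nM to 16000 nM.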

Compound 4, half-maximal effective concentration: 9500 nM
The estimate for compound 4 lay 1.1-fold (0.02 log units) above the measured number; the range from low to high includes it.
By their numbers in this assay, from the lowest: compounds 1, 4, 3 and 2 (each within the scatter of the next).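

In this assay, within the data shown here, this is the first direct look at the aromatic carbon ortho to a methoxy group and para to a large group, and fluoro in place of hydrogen there gives a 1.0-fold lower number from compound 3 to compound 4 (0.01 log units; within the scatter) so the two compounds cannot be told apart. The group at the methoxy position also gives no separation, with methoxy in place of fluoro giving a 1.0-fold higher number from compound 1 to compound 4 (0.02 log units; within the scatter) and methoxy in place of trifluoromethyl giving a 1.2-fold lower number from compound 2 to compound 4 (0.08 log units; within the scatter) in the same comparison. No measurement offered here explains why these four compounds sit so close together.

As far as these compounds go, whether an amine or a carboxylic acid on this carbon would move the number beyond the scatter remains open. So does the outcome of a longer chain in place of the methoxy group.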